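The source may report more compounds than this note shows. Statements on the series, on what has been measured and on what is new or still open speak of the compounds shown alone.

In a functional assay on SK-BR-3 cells (Homo sapiens) for antiproliferative activity (on this read-out higher numbers stand for weaker inhibition and lower numbers for stronger inhibition), compound 1 `CC(C)=CCc1cc(C(=O)Nc2cc3ccc(OCCCNC(C)C)c(C)c3oc2=O)ccc1O` gives 750 nM and compound 2 `CC(C)=CCc1cc(C(=O)Nc2cc3ccc(OCCCNCCO)c(C)c3oc2=O)ccc1O` gives 610 nM. Compound 2 therefore stands within the scatter of compound 1, and the pair cannot be ranked. The next structure, compound 3 `CC(C)=CCc1cc(C(=O)Nc2cc3ccc(OCCCNc4ccccc4)c(C)c3oc2=O)ccc1O`, carries phenyl in place of 2-hydroxyethyl on an amine nitrogen. Going by the values given here, only one measured step bears on this change: a 1.2-fold lower number from compound 1 to compound 2 (0.09 log units; within the scatter), which exchanged isopropyl for 2-hydroxyethyl on an amine nitrogen and stayed within the scatter. Among the compounds with values here, that step is a weak guide, since neither group in it contains a ring, and the series offers no measured example of an aromatic ring at this place. On the evidence of that single step, no clear direction can be assigned in this assay, and no change beyond the scatter is expected. The expected step is a 1.1-fold higher number from compound 2 to compound 3 (0.06 log units; within the scatter), with a wide margin on either side. For compound 3 the estimated value is 700 nM, with an expected range of 250 nM to 2000 nM.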

Compound 3, half-maximal inhibitory concentration: > 50000 nM
Compound 3: no number, only a limit (the forecaster's own chance of this, stated with the estimate: 3%); at least 71-fold (1.85 log units) between middle value and limit.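

In this assay compound 3 gives > 50000 nM, which is a limit of the assay and not a number: the limit of > 50000 nM in this assay, at which 1 of the 3 values shown sits. Read against the two amines with no ring, this is an at least 81-fold higher number from compound 2 to compound 3 (1.91 log units; beyond the scatter) and an at least 66-fold higher number from compound 1 to compound 3 (1.82 log units; beyond the scatter). Going by these compounds alone, the group on this amine nitrogen therefore matters: isopropyl and 2-hydroxyethyl stand within the scatter of each other, whereas phenyl, with its six-membered aromatic ring of carbon only, gives the first change at this place beyond the scatter.

The compounds shown leave open whether the step follows from the ring itself, from its being aromatic, or from its sitting directly on the amine nitrogen. A cyclohexyl group or a benzyl group on the same nitrogen would separate these readings, and a pyridyl ring would show whether a ring nitrogen alters the outcome.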